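Same substituent swap tried on a rearranged core

A few compounds are considered here, and "the series" means these few. Any claim that something is new, unique, unknown or untested is made for them only; others in the source may bear on it.

Four compounds share one kind of structure and differ in two ways: in how the atoms of the core are joined, and in the group carried on an aromatic nitrogen. Compound 1 `CC1(C)CCc2cc(C(=O)/C=C/c3ccc(OCc4cn(-c5ccc(Br)cc5)nn4)cc3)c(O)cc2O1` and compound 2 `Cc1c(-n2cc(COc3ccc(/C=C/C(=O)c4cc5c(cc4O)OC(C)(C)CC5)cc3)nn2)cccc1[N+](=O)[O-]` have one core; compound 3 `CC1(C)CCc2c(ccc(C(=O)/C=C/c3ccc(OCc4cn(-c5ccc(Br)cc5)nn4)cc3)c2O)O1` and compound 4 `Cc1c(-n2cc(COc3ccc(/C=C/C(=O)c4ccc5c(c4O)CCC(C)(C)O5)cc3)nn2)cccc1[N+](=O)[O-]` have the other. Compound 3 is built from the same atoms as compound 1, joined differently, and the difference between the two cores is not broken down here.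

In a functional assay on A549 cells (Homo sapiens) for antiproliferative activity, read by MTT assay (a lower number here means a stronger inhibitor, a higher number a weaker inhibitor), compound 1 gives 80000 nM. Compound 2 differs from it by one change, (2-methyl-3-nitrophenyl in place of 4-bromophenyl on an aromatic nitrogen), and in this assay compound 2 gives 65900 nM. That change made a 1.2-fold lower number from compound 1 to compound 2 (0.08 log units; within the scatter). On the other core, compound 3 gives 129000 nM in this assay; its number and that of compound 1 lie within the scatter of each other, as do those of compound 3 and compound 2.

Compound 4 carries the same change as compound 2, (2-methyl-3-nitrophenyl in place of 4-bromophenyl on an aromatic nitrogen), with the place lines matching word for word, so it is the same change on a different core. Compound 4 has not yet been measured. Because the earlier instance gave a 1.2-fold lower number from compound 1 to compound 2 (0.08 log units; within the scatter), the step from compound 3 to compound 4 is expected to be a 1.2-fold lower number from compound 3 to compound 4 (0.09 log units; within the scatter). Compound 4 is thus estimated at 106000 nM in this assay, expected between 50000 nM and 250000 nM, resting on one prior example of the change and on compound 3.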

Compound 4, half-maximal inhibitory concentration: "not active" (no number reported)
For compound 4 the study gives words and no number; the estimate stays without a comparison.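

In this assay, within the data shown here, compound 4 is reported only in words, as not active, without a number, so no step from compound 3 to compound 4 can be read. The compounds shown leave open whether 2-methyl-3-nitrophenyl in place of 4-bromophenyl does the same on the core of compound 3 as on the core of compound 1. Nothing shown here offers an explanation for this result.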